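A Chloro Substituent on the Benzyl Ring of Compound 2

The source may report more compounds than this note shows. Statements on the series, on what has been measured and on what is new or still open speak of the compounds shown alone.

Of the compounds shown here, two sharing one core have been measured in a functional assay on MCF7 cells (Homo sapiens) for cytotoxicity, read by MTT assay, with a stated time of 24 h, tested at 32 ug/mL; on this read-out lower numbers stand for a weaker effect and higher numbers for a stronger effect at the one concentration tested. Compound 1 `CN(C)/C=C/N1CCN(CC(=O)Nc2ccc(-c3nc(-c4ccccc4)c(-c4ccccc4)n3C)cc2)CC1` gives 25.8% in this assay. For the measured compounds named here, compound 2 `Cn1c(-c2ccc(NC(=O)CN3CCN(Cc4ccccc4)CC3)cc2)nc(-c2ccccc2)c1-c1ccccc1` gives 33.6% in this assay, the higher of the two numbers, though the single step of a number 7.8 percentage points higher from compound 1 to compound 2 (within the scatter) lies within the scatter, so the two compounds cannot be told apart on this read-out.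

Compound 3 `Cn1c(-c2ccc(NC(=O)CN3CCN(Cc4ccc(Cl)cc4)CC3)cc2)nc(-c2ccccc2)c1-c1ccccc1` has not yet been measured. It differs from compound 2 in one place: chloro in place of hydrogen on an aromatic carbon. Going by the values given here, no measured step concerns a chloro group on this ring; the only step in hand, a number 7.8 percentage points higher from compound 1 to compound 2 (within the scatter), exchanged the whole group on the ring nitrogen and stayed within the scatter. A single chlorine added on the benzyl ring is a smaller change than that, and the data give no ground to expect a shift beyond the scatter in either direction. The step from compound 2 to compound 3 is therefore expected to be a number 2.4 percentage points higher from compound 2 to compound 3 (within the scatter). Compound 3 is estimated at 36%, with a range from 22% to 50%, in this assay.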

Compound 3, a percentage reported as activity, at one concentration (the size of the read-out at that concentration, not a potency): 52.8%
Compound 3: the middle estimate sits 16.8 percentage points below what was measured; measured number outside the range, above it.
By their numbers in this assay, from the lowest: compounds 1 and 2 (each within the scatter of the next); then compound 3.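

In this assay, a single chlorine on the benzyl ring, para to a large group, gives a number 19.2 percentage points higher from compound 2 to compound 3 (beyond the scatter). This shows that a one-atom change at this aromatic carbon can register on the read-out, whereas the exchange of the whole group on the ring nitrogen between compound 1 and compound 2 stayed within the scatter. The 4-chlorobenzyl group also stands clear of the 2-(dimethylamino)ethenyl group, with a number 27 percentage points higher from compound 1 to compound 3 (beyond the scatter), so compound 3 is separated from both earlier compounds, and nothing in hand explains the size of this gain.

The compounds shown leave open whether the gain is particular to chloro or would also appear with a fluoro, methyl or methoxy group on the same aromatic carbon. They also leave open whether a chloro on another carbon of the benzyl ring would behave alike, and, since each number comes from one concentration, how compound 3 compares in potency with compound 2.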